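A Second Chloro on the Core of a Benzylpurine

A few compounds are considered here, and "the series" means these few. Any claim that something is new, unique, unknown or untested is made for them only; others in the source may bear on it.

Measured compounds in this study:
compound 1, `ClCc1ccccc1Cn1cnc2c(Cl)nc(Cl)nc21`, "not determined" (no result reported)
compound 2, `ClCc1cccc(Cn2cnc3c(Cl)ncnc32)c1`, 3090 nM
compound 3, `ClCc1ccc(Cn2cnc3nc(Cl)nc(Cl)c32)cc1`, 17400 nM

In a functional assay on COLO 205 cells (Homo sapiens) for cytotoxicity, read by sulforhodamine B assay, with a stated time of 48 h (on this read-out lower numbers stand for stronger inhibition of growth and higher numbers for weaker inhibition of growth), compound 2 gives 3090 nM, the lower of the two numbers obtained so far. Compound 3 gives 17400 nM in this assay, and the gap between the two lies beyond the scatter of repeated measurements. Compound 1 gives "not determined" (no result reported) in this assay, so nothing can be said of where it stands.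

Compound 4, `ClCc1cccc(Cn2cnc3c(Cl)nc(Cl)nc32)c1`, has not yet been measured. It differs from compound 2 in one place: chloro in place of hydrogen on an aromatic carbon. Within the data shown here, no pair of measured compounds differs in a single place, so there is no measured step that isolates the effect of this change. Compound 3 also carries two chloro groups on its core, but its benzyl chloride is placed differently, so its number cannot be read as a clean comparison.

Among the measured compounds shown here, with no direct precedent, the step from compound 2 to compound 4 is expected to be small, possibly within the scatter, with no confident direction; the estimated step is a 1.1-fold higher number from compound 2 to compound 4 (0.05 log units; within the scatter). Compound 4 is therefore expected to give about 3500 nM in this assay, within a range of 1000 nM to 12000 nM.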

Compound 4, concentration for 50% growth inhibition: 2230 nM
Beside the measured number, compound 4's estimate is 1.6-fold (0.20 log units) above it; measured number inside the range.
By their numbers in this assay, from the lowest: compounds 4 and 2 (each within the scatter of the next); then compound 3.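

Among these compounds, the pair of compound 2 and compound 4 gives the first measured step here that isolates a single change. In this assay, chloro in place of hydrogen on an aromatic carbon of the six-membered aromatic ring with 2 nitrogen, between two ring nitrogen atoms, amounts to a 1.4-fold lower number from compound 2 to compound 4 (0.14 log units; within the scatter), so this position accepts a chloro group with no change that can be told from repeat measurement, and the two compounds cannot be ranked against each other. Nothing measured in this set speaks to the reason for this outcome.

On these data alone, whether a different group at this same position, such as an amine, a methoxy group or a longer chain, would also leave the number level with those of compound 2 and compound 4 remains open. Also open is whether the same single change would give a step of similar size with the benzyl chloride placed as in compound 3, as the compounds shown hold no such pair.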